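A few compounds are considered here, and "the series" means these few. Any claim that something is new, unique, unknown or untested is made for them only; others in the source may bear on it.

Measured compounds:
compound 1, `CCOc1ccccc1-c1ccc(-c2nc3cnccc3cc2C#N)cc1`, 3.8
compound 2, `CC[C@@H](Nc1c(C#N)c(-c2ccc(-c3cccc(Cl)c3F)cc2)nc2cnccc12)C(N)=O`, 3.1
compound 3, `CCOc1ccccc1-c1ccc(-c2nc3cnccc3c(N[C@H](CC)C(=O)NS(C)(=O)=O)c2C#N)cc1`, 2.2

In a physicochemical assay for lipophilicity, read by HPLC, at pH 7.5 (on this read-out higher numbers stand for higher lipophilicity and lower numbers for lower lipophilicity), compound 1 stands highest of the three numbers, with compound 2 nearest and compound 3 furthest. Compound 4, `CCOc1ccccc1-c1ccc(-c2nc3cnccc3c(N[C@H](CC)C(N)=O)c2C#N)cc1`, has not yet been measured in this assay. It is built from compound 1 by the change ((1-carbamoylpropyl)amino in place of hydrogen on an aromatic carbon).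

Among the compounds with values here, one measured step bears on this change: a number 1.60 log units lower from compound 1 to compound 3 (beyond the scatter). There the entering group was larger than the (1-carbamoylpropyl)amino group of compound 4 and sat at the same place on the core. Compound 2 carries that same (1-carbamoylpropyl)amino group, though with a different outer ring, and in this assay compound 2 gives 3.1. Taken together, a drop beyond the scatter is expected, but a smaller one than from compound 1 to compound 3.

For compound 4 the expected step is a number 0.70 log units lower from compound 1 to compound 4 (beyond the scatter). Compound 4 is therefore estimated at 3.1 in this assay, within a range from 2.6 to 3.6.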

Compound 4, distribution coefficient: 3
Estimate against measurement, compound 4: 0.10 log units above; measured number inside the range.
By their numbers in this assay, from the lowest: compound 3; then compounds 4 and 2 (each within the scatter of the next); then compound 1.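

In this assay, the (1-carbamoylpropyl)amino group on this aromatic carbon, ortho to the cyano group, brings a clear step on its own (a number 0.80 log units lower from compound 1 to compound 4 (beyond the scatter)). Hydrogen in place of methylsulfonyl on the amide-type nitrogen gives a step of the same size in the opposite direction (a number 0.80 log units higher from compound 3 to compound 4 (beyond the scatter)), so the large fall seen with the bigger group splits into two equal parts. With this group in place, 2-ethoxyphenyl in place of 3-chloro-2-fluorophenyl leaves the two compounds within the scatter of each other (a number 0.10 log units lower from compound 2 to compound 4 (within the scatter)).

Nothing measured here gives a reason for these steps. The compounds shown also leave open how this position would read with a carboxylic acid in place of the carbamoyl group, or with a longer chain in place of the ethyl chain.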